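The compounds below may be only part of what the source reports. "The series", "measured", "known", "first", "only" and "open" are said of these compounds alone.

Three compounds built on one shared core were tested in a functional assay on HCT-15 cells (Homo sapiens) for inhibition, read by MTT assay, with a stated time of 72 h; on this read-out lower numbers stand for stronger inhibition and higher numbers for weaker inhibition. Compound 1 `COc1ccc(CNCc2c(OC)cc(Oc3cccc(Nc4ccccc4)c3)cc2OC)cc1` gives 2650 nM. Compound 2 `COc1cc(Oc2cccc(Nc3ccccc3)c2)cc(OC)c1CNCc1ccc(F)cc1` gives 3640 nM, and compound 3 `COc1cc(Oc2cccc(Nc3ccccc3)c2)cc(OC)c1CNCCNC(C)=O` gives 5090 nM. Compound 3 holds the largest of these three numbers, yet the steps of a 1.9-fold higher number from compound 1 to compound 3 (0.28 log units; within the scatter) and a 1.4-fold higher number from compound 2 to compound 3 (0.15 log units; within the scatter) both lie within the usual scatter, so the three compounds cannot be separated on this evidence. Compound 4 `COc1cc(Oc2cccc(Nc3ccccc3)c2)cc(OC)c1CNCc1ccc(C)cc1` has not been measured. It differs from compound 3 in one place: 4-methylphenyl in place of acetamidomethyl on a saturated chain carbon bound to an amine nitrogen. This change runs opposite to the two steps just named, in which acetamidomethyl took the place of a 4-methoxyphenyl or a 4-fluorophenyl group on that same chain carbon. Restoring an aromatic ring there is therefore expected to move the number the other way by a comparably small step, a 1.7-fold lower number from compound 3 to compound 4 (0.23 log units; within the scatter), which may not exceed the scatter. Compound 4 is estimated at 3000 nM, within a range from 1500 nM to 6000 nM.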

Compound 4, half-maximal inhibitory concentration: 5400 nM
For compound 4 the middle estimate is 1.8-fold (0.26 log units) below the measured one; the measured number falls inside the stated range.
By their numbers in this assay, from the lowest: compounds 1, 2, 3 and 4 (each within the scatter of the next, the first and the last beyond it).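

Placed on the chain carbon bound to the amine nitrogen, the 4-methylphenyl ring, with no hydrogen-bond donors or acceptors, is not distinguishable from the acetamidomethyl group, which has one of each, as a 1.1-fold higher number from compound 3 to compound 4 (0.03 log units; within the scatter) shows. Among the compounds shown here, on the ring itself, the outcome depends on which pair is compared: a 1.5-fold higher number from compound 2 to compound 4 (0.17 log units; within the scatter) cannot separate methyl from fluoro, whereas a 2.0-fold higher number from compound 1 to compound 4 (0.31 log units; beyond the scatter) gives methyl in place of methoxy the only step in this set that passes the scatter, though only modestly. No supporting measurement is available to explain either result.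

Going by these compounds, whether this small gap between methoxy and methyl extends to other groups on that ring, such as hydroxy or chloro, remains open. So does the effect of a carboxylic acid or a longer chain on the chain carbon.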